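Swapping Imidazole for Carboxyphenyl at the Ring Amine

This account rests on a few compounds, and the source may have more. Where it says the series, first, only, none or still open, it means among the compounds named here.

Compound 1, `Clc1cc(Cl)cc(CO[C@H]2CCCN(Cc3ccccn3)[C@H]2c2ccccc2)c1`, reaches only the assay limit of > 200000 nM in an assay on isolated protein for activation of cGMP-dependent protein kinase 1 (Homo sapiens), read by ADP-Glo, with stated times of 120 min and 40 min; on this read-out higher numbers stand for an effect only at larger amounts of compound and lower numbers for an effect already at smaller amounts.
Compound 2, `Cn1ccnc1CN1CCC[C@H](OCc2cc(Cl)cc(Cl)c2)[C@@H]1c1ccccc1`, gives 165000 nM in this assay.
Compound 3, `Clc1cc(Cl)cc(CO[C@H]2CCCN(Cc3ncc[nH]3)[C@H]2c2ccccc2)c1`, gives 47000 nM in this assay.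

Compound 3 therefore holds the lowest of the two numbers shown, and the gap to the nearest is a 3.5-fold lower number from compound 2 to compound 3 (0.55 log units; beyond the scatter). Compound 4, `COc1ccc(C(=O)O)cc1CN1CCC[C@H](OCc2cc(Cl)cc(Cl)c2)[C@@H]1c1ccccc1`, differs from compound 3 by 5-carboxy-2-methoxyphenyl in place of 1H-imidazol-2-yl on a saturated chain carbon bound to an amine nitrogen in a ring. Among the compounds with values here, two measured steps concern the same place: an at least 4.2-fold lower number from compound 1 to compound 3 (0.62 log units; beyond the scatter) and a 3.5-fold lower number from compound 2 to compound 3 (0.55 log units; beyond the scatter). Each earlier change there brought the number down, though the 5-carboxy-2-methoxyphenyl group is unlike either replacement. A modest further fall is expected, a 2.4-fold lower number from compound 3 to compound 4 (0.37 log units; beyond the scatter). For compound 4 in this assay the estimate is 20000 nM, expected between 3000 nM and 150000 nM.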

Compound 4, half-maximal effective concentration: 123000 nM
Compound 4: the middle estimate sits 6.2-fold (0.79 log units) below what was measured; the measured number falls inside the stated range.
By their numbers in this assay, from the lowest: compound 3; then compounds 4 and 2 (each within the scatter of the next). At a limit, above all of these: compound 1.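

Within the data shown here, at this place, on a saturated chain carbon bound to an amine nitrogen in a ring, the 5-carboxy-2-methoxyphenyl group is the first replacement to lose ground against 1H-imidazol-2-yl in this assay, with a 2.6-fold higher number from compound 3 to compound 4 (0.42 log units; beyond the scatter). It cannot be told apart from the methylated imidazole, with a 1.3-fold lower number from compound 2 to compound 4 (0.13 log units; within the scatter), and the comparison with pyridin-2-yl gives an at least 1.6-fold lower number from compound 1 to compound 4 (0.21 log units; that floor lies within the scatter). Compound 1 stands at a limit: the limit of > 200000 nM in this assay, at which 1 of the 4 values shown sits. From the compounds shown here alone, the carboxylic acid and the methoxy enter together, so their separate contributions remain open. A phenyl ring carrying only one of them would divide the two.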